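The compounds below may be only part of what the source reports. "The series", "measured", "known", "first", "only" and "open" are said of these compounds alone.

Measured compounds:
compound 1, `N#CC1=C(N)N(c2ccc(S(N)(=O)=O)cc2)C2=C(C(=O)CCC2)C1c1ccc(Cl)cc1Cl`, in a functional assay on Ehrlich cells (Mus musculus) for cytotoxicity, read by trypan blue exclusion, with a stated time of 2 h, tested at 10 ug/mL (on this read-out lower numbers stand for a weaker effect and higher numbers for a stronger effect at the one concentration tested), compound 1 gives 40%
compound 2, `N#CC1=C(NC(=O)C2CC2)N(c2ccc(S(N)(=O)=O)cc2)C2=C(C(=O)CCC2)C1c1ccc(Cl)cc1Cl`, in this assay compound 2 gives 20%

Among the measured compounds shown here, compound 2 stands lowest of the two numbers in this assay, and the single measured step, a number 20 percentage points lower from compound 1 to compound 2 (beyond the scatter), separates it from compound 1. Compound 3, `N#CC1=C(NC(=O)c2ccccc2)N(c2ccc(S(N)(=O)=O)cc2)C2=C(C(=O)CCC2)C1c1ccc(Cl)cc1Cl`, is not yet measured. It differs from compound 2 by phenyl in place of cyclopropyl on a carbonyl carbon. For the measured compounds named here, no measured step exchanges one acyl group for another. Going by the values given here, the one step that bears on the amide at all, a number 20 percentage points lower from compound 1 to compound 2 (beyond the scatter), concerns acylation of the amine nitrogen and shows only that the amide sits lower than the free amine. Compound 3 keeps the amide. Its number in this assay is therefore expected close to that of compound 2, with no step beyond the scatter expected: a number 2 percentage points higher from compound 2 to compound 3 (within the scatter). Compound 3 is estimated at 22%, with an expected range from 8% to 40%.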

Compound 3, a percentage reported as activity, at one concentration (the size of the read-out at that concentration, not a potency): 50%
The estimate for compound 3 lay 28 percentage points below the measured number; measured number outside the range, above it.
By their numbers in this assay, from the lowest: compound 2; then compounds 1 and 3 (each within the scatter of the next).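

In this assay the group on the carbonyl carbon matters and not only the presence of the amide: phenyl in place of cyclopropyl gives a number 30 percentage points higher from compound 2 to compound 3 (beyond the scatter). Acylation of the amine nitrogen therefore does not by itself go with a lower number, since benzoyl in place of hydrogen gives a number 10 percentage points higher from compound 1 to compound 3 (within the scatter), and compound 3 goes against any reading of the earlier step as a general effect of the amide. No available measurement accounts for the difference between the two acyl groups.

With only cyclopropylcarbonyl and benzoyl shown, it stays open whether the aromatic ring or the larger count of carbon atoms goes with the higher number. An acetyl group, a longer alkyl chain on the carbonyl or a benzoyl group carrying a methoxy group would test this.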